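This account rests on a few compounds, and the source may have more. Where it says the series, first, only, none or still open, it means among the compounds named here.

Of the compounds shown here, three built on one shared macrocyclic core have been measured so far, and they differ only in the aromatic ring attached through oxygen to the six-membered saturated ring. Compound 1 `CC[C@@H]1/C=C(\C)C[C@H](C)C[C@H](OC)[C@H]2O[C@@](O)(C(=O)C(=O)N3CCCC[C@H]3C(=O)O[C@H](/C(C)=C/[C@@H]3CC[C@@H](Oc4cccc(OC)c4)[C@H](OC)C3)[C@H](C)[C@@H](O)CC1=O)[C@H](C)C[C@@H]2OC` gives 3.4 nM in a functional assay on cells for inhibition, with Murine T-cell line (Mus musculus) as the target; a higher number here means a weaker inhibitor, a lower number a stronger inhibitor. Compound 3 `CC[C@@H]1/C=C(\C)C[C@H](C)C[C@H](OC)[C@H]2O[C@@](O)(C(=O)C(=O)N3CCCC[C@H]3C(=O)O[C@H](/C(C)=C/[C@@H]3CC[C@@H](Oc4ccc(OC)cc4)[C@H](OC)C3)[C@H](C)[C@@H](O)CC1=O)[C@H](C)C[C@@H]2OC` gives 1.4 nM in this assay, and the single-point step is a 2.4-fold lower number from compound 1 to compound 3 (0.39 log units; beyond the scatter). Compound 2 `CC[C@@H]1/C=C(\C)C[C@H](C)C[C@H](OC)[C@H]2O[C@@](O)(C(=O)C(=O)N3CCCC[C@H]3C(=O)O[C@H](/C(C)=C/[C@@H]3CC[C@@H](O)[C@H](Oc4ccc(OC)cc4)C3)[C@H](C)[C@@H](O)CC1=O)[C@H](C)C[C@@H]2OC` gives 0.9 nM in this assay, the lowest of the three numbers; compound 3 lies within the scatter of it, while compound 1 lies beyond.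

Compound 4 `CC[C@@H]1/C=C(\C)C[C@H](C)C[C@H](OC)[C@H]2O[C@@](O)(C(=O)C(=O)N3CCCC[C@H]3C(=O)O[C@H](/C(C)=C/[C@@H]3CC[C@@H](O)[C@H](Oc4ccc(C)cc4)C3)[C@H](C)[C@@H](O)CC1=O)[C@H](C)C[C@@H]2OC` is compound 2 with methyl in place of methoxy on an aromatic carbon. Within the data shown here, no measured step bears directly on this swap: the only step available moves the methoxy to another spot on the ring rather than removing its oxygen, and it was modest. All three measured numbers sit in a narrow band, so the expectation is a small step, likely not beyond the scatter, with no clear direction.

Compound 4 is therefore expected to give about 1.2 nM in this assay, with a range from 0.4 nM to 4 nM. The estimated step is a 1.3-fold higher number from compound 2 to compound 4 (0.12 log units; within the scatter).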

Compound 4, half-maximal inhibitory concentration: 2.6 nM
Beside the measured number, compound 4's estimate is 2.2-fold (0.34 log units) below it; the range from low to high includes it.
By their numbers in this assay, from the lowest: compounds 2, 3, 4 and 1 (each within the scatter of the next, the first and the last beyond it).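

In this assay, the swap of methoxy for methyl on this aromatic carbon, para to a large group, gives a 2.9-fold higher number from compound 2 to compound 4 (0.46 log units; beyond the scatter): a modest step, but one beyond the scatter. Among these compounds, the only earlier step moved the methoxy around the ring, whereas this one keeps the place fixed and changes the group, showing that the number responds to what sits at this position as well as to where the methoxy sits. The response is limited, as compound 4 gives 2.6 nM without the oxygen of the methoxy, but nothing available here explains why the number rises.

Going by these compounds, a single swap cannot separate the loss of the oxygen from the change in the group as a whole, so it remains open how a hydroxyl, a fluorine, an ethyl or an ethoxy at the same place would compare with methoxy and methyl. On these data alone, it is also open whether the same swap would give a step of similar size on compound 3, where the aromatic ring is attached through oxygen at a different carbon of the saturated ring.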